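The source may hold more compounds than are shown below. What is called first, only, known or untested is meant among the compounds shown, and "the series" means these compounds.

Compound 1 `COc1ccc(-c2csc(N)c2C(=O)OCc2ccc(C)cc2)cc1OC` gives 50% in an assay on isolated protein for inhibition of protein kinase C zeta type (Homo sapiens), with stated times of 1 h and 2.5 min, tested at 30 uM; on this read-out higher numbers stand for more inhibition at the one concentration tested (going by the name of the read-out) and lower numbers for less inhibition. Compound 2 `COc1ccc(-c2csc(N)c2C(=O)OCc2ccncc2)cc1OC` gives 53% in this assay.

For the measured compounds named here, on these two numbers compound 2 stands highest, with compound 1 nearest, the only measured step being a number 3 percentage points higher from compound 1 to compound 2 (within the scatter), which leaves the two within the scatter of each other. Compound 3 `COc1ccc(-c2csc(N)c2C(=O)O)cc1OC` differs from compound 2 by hydrogen in place of (pyridin-4-yl)methyl on an oxygen next to a carbonyl group. Going by the values given here, the one measured step bears on this change only loosely: it exchanged one ring for another on the same chain and showed that this exchange hardly moved this assay, but no measured step removes the whole group from the oxygen next to the carbonyl group, so the weight of that group is unknown. A modest fall beyond the scatter is therefore expected, a number 13 percentage points lower from compound 2 to compound 3 (beyond the scatter), with wide uncertainty. Compound 3 is estimated at 40%, in the range 10% to 70%.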

Compound 3, a percentage reported as inhibition, at one concentration (the size of the read-out at that concentration, not a potency): 65%
Beside the measured number, compound 3's estimate is 25 percentage points below it; the range from low to high includes it.
By their numbers in this assay, from the lowest: compounds 1 and 2 (each within the scatter of the next); then compound 3.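

The first measured step exchanged one ring for another at the end of the chain and left this assay within the scatter, so it could not show what the group as a whole contributes. Removing the group shows that inhibition does not depend on it: hydrogen in place of (pyridin-4-yl)methyl on an oxygen next to a carbonyl group gives a number 12 percentage points higher from compound 2 to compound 3 (beyond the scatter), and hydrogen in place of 4-methylbenzyl gives a number 15 percentage points higher from compound 1 to compound 3 (beyond the scatter). Nothing given here explains why the shorter (pyridin-4-yl)methoxy to hydroxy change is accompanied by this modest rise.

The compounds shown leave open whether a single methyl on that oxygen would read like the hydrogen of compound 3 or like the larger groups of compound 1 and compound 2. They also leave open how an amide nitrogen in place of that oxygen would read.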